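Hydroxy and methoxy aryl changes in the acetyl series

The source may report more compounds than this note shows. Statements on the series, on what has been measured and on what is new or still open speak of the compounds shown alone.

Measured in a functional assay on the whole organism (strain albino) with Mus musculus as the target, with a stated time of 0.5 h; on this read-out lower numbers stand for an effect already at smaller amounts and higher numbers for an effect only at larger amounts of compound:
- compound 1 `COc1ccc(C2CC(Nc3nc4ccc(C)cc4s3)=NN2C(C)=O)cc1`: 39.4 umol/kg
- compound 2 `COc1ccc(C2CC(Nc3nc4ccc(Cl)cc4s3)=NN2C(C)=O)cc1O`: 132 umol/kg
- compound 3 `CC(=O)N1N=C(Nc2nc3ccc(C)cc3s2)CC1c1ccc(O)cc1`: 54.3 umol/kg

Compound 3 stands within the scatter of compound 1, and its number is clearly lower than that of compound 2. The next structure is compound 4 `COc1ccc(C2CC(Nc3nc4ccc(C)cc4s3)=NN2C(C)=O)cc1O`, with 3-hydroxy-4-methoxyphenyl in place of 4-hydroxyphenyl on a saturated ring carbon.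

Going by the values given here, the one measured step that bears on this change is a 1.4-fold higher number from compound 1 to compound 3 (0.14 log units; within the scatter), hydrogen in place of methyl on an oxygen on an aromatic ring. That step lies within the scatter, so the oxygen substituent has not yet shown a clear effect on this read-out. Compound 2 already carries 3-hydroxy-4-methoxyphenyl, but on a different core, and at 132 umol/kg it only argues for a wider upper range.

No clear move is expected, and the expected step is a 1.2-fold higher number from compound 3 to compound 4 (0.08 log units; within the scatter). For compound 4 the estimate is 65 umol/kg, with an expected range of 32 umol/kg to 130 umol/kg.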

Compound 4, dose for half-maximal effect: 75.6 umol/kg
For compound 4 the middle estimate is 1.2-fold (0.07 log units) below the measured one; measured number inside the range.
By their numbers in this assay, from the lowest: compounds 1, 3, 4 and 2 (each within the scatter of the next, the first and the last beyond it).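

In this assay, 3-hydroxy-4-methoxyphenyl in place of 4-hydroxyphenyl on the saturated ring carbon gives a 1.4-fold higher number from compound 3 to compound 4 (0.14 log units; within the scatter) and so does not separate the two aryl groups, while hydroxy in place of hydrogen on an aromatic carbon gives a 1.9-fold higher number from compound 1 to compound 4 (0.28 log units; within the scatter) and also stays inside the scatter. With 3-hydroxy-4-methoxyphenyl held constant, methyl in place of chloro on an aromatic carbon gives a 1.7-fold lower number from compound 2 to compound 4 (0.24 log units; within the scatter) so that every single change shown so far remains within the scatter. No measurement at hand accounts for these small steps.

From the compounds shown here alone, whether this position tolerates larger departures stays open: an amine or a carboxylic acid on the aryl ring could still move the number beyond the scatter. A longer chain in place of the acetyl group on the neighbouring ring atom is equally untested in the compounds shown.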